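The source may report more compounds than this note shows. Statements on the series, on what has been measured and on what is new or still open speak of the compounds shown alone.

Measured so far:
compound 1, `CCCC[C@@H](CCn1cncn1)c1ccc(Cl)cc1Cl`, an ADME assay on HEp-2 cells (Homo sapiens) for cytotoxicity, read by MTT assay, with a stated time of 3 days; on this read-out lower numbers stand for higher toxicity in this test and higher numbers for lower toxicity in this test: 6.5 ug/mL
compound 2, `Clc1ccc([C@@H](CCn2cncn2)Cc2ccccc2)c(Cl)c1`, this assay: 11.1 ug/mL

Compound 2 has the highest of the two numbers, but its gap to compound 1 lies within the scatter, so the two cannot be told apart. Compound 3, `Clc1ccc([C@H](CCn2cncn2)Cc2ccccc2)c(Cl)c1`, is its mirror form: the two compounds have the same atoms and bonds and differ only in configuration as drawn: 1 of 1 stereo elements differ; a stereocentre at a saturated chain carbon is drawn R in compound 2 and S in compound 3. For the measured compounds named here, no step between measured compounds shows what such a change does here, and no other difference is present. The expected step is a 1.0-fold lower number from compound 2 to compound 3 (0.00 log units; within the scatter), not beyond the scatter. Compound 3 is therefore estimated at 11 ug/mL, in the range 5 ug/mL to 25 ug/mL.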

Compound 3, half-maximal cytotoxic concentration: 4.9 ug/mL
Beside the measured number, compound 3's estimate is 2.2-fold (0.35 log units) above it; measured number outside the range, below it.
By their numbers in this assay, from the lowest: compounds 3, 1 and 2 (each within the scatter of the next, the first and the last beyond it).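

Mirror forms need not give the same number in this assay: the change of configuration at this saturated chain carbon gives a 2.3-fold lower number from compound 2 to compound 3 (0.36 log units; beyond the scatter). This modest step can be put down to that one stereocentre for a simple reason: the fact that compounds 2 and 3 differ only in the configuration as drawn

Phenyl in place of propyl on the chain carbon gives a 1.3-fold lower number from compound 1 to compound 3 (0.12 log units; within the scatter), so that swap shows no readable change.

From the compounds shown here alone, whether the mirror form of compound 1 would show a similar step stays open. So does the effect of a longer chain or an amine on this carbon.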